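Compound 4 against the S-substituted analogues

The source may report more compounds than this note shows. Statements on the series, on what has been measured and on what is new or still open speak of the compounds shown alone.

Compound 1 `COc1cc(-c2nnc(S)n2-c2ccc(N(C)C)cc2)cc(OC)c1OC`: > 60000 nM, a limit of the assay
Compound 2 `COc1cc(-c2nnc(SCc3ccc(F)cc3)n2-c2ccc(N(C)C)cc2)cc(OC)c1OC`: 46500 nM
Compound 3 `COc1cc(-c2nnc(SCC(=O)c3ccccc3)n2-c2ccc(N(C)C)cc2)cc(OC)c1OC`: 38600 nM
Compound 4 `COc1cc(-c2nnc(SCC(=O)c3ccc(F)cc3)n2-c2ccc(N(C)C)cc2)cc(OC)c1OC`: not yet measured

In a functional assay on PC-3 cells (Homo sapiens) for inhibition, read by MTT assay, with a stated time of 48 h (a lower number here means a stronger inhibitor, a higher number a weaker inhibitor), compound 2 gives 46500 nM and compound 3 gives 38600 nM, two values within the scatter of each other. Among the measured compounds shown here, the only other reading, for compound 1, is a limit.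

The change to compound 4 is fluoro in place of hydrogen on an aromatic carbon, benzoyl to (4-fluorophenyl)carbonyl. For the measured compounds named here, no measured step isolates this change. The nearest evidence is a 1.2-fold lower number from compound 2 to compound 3 (0.08 log units; within the scatter), and the substitutions on sulfur give an at least 1.2-fold lower number from compound 1 to compound 2 (0.11 log units; that floor lies within the scatter) and an at least 1.5-fold lower number from compound 1 to compound 3 (0.19 log units; that floor lies within the scatter). With these steps this small, nothing beyond the scatter is expected in this assay. The expected size is a 1.1-fold lower number from compound 3 to compound 4 (0.03 log units; within the scatter). Compound 4 is expected at 36000 nM, with an estimated range of 18000 nM to 60000 nM.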

Compound 4, half-maximal inhibitory concentration: 42300 nM
Estimate against measurement, compound 4: 1.2-fold (0.07 log units) below; low and high end bracket the measured number.
By their numbers in this assay, from the lowest: compounds 3, 4 and 2 (each within the scatter of the next). At a limit, above all of these: compound 1.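

Fluoro in place of hydrogen on the benzoyl group gives a 1.1-fold higher number from compound 3 to compound 4 (0.04 log units; within the scatter) in this assay, the only direct reading of this change in the series, so this aromatic carbon takes fluoro with no shift beyond the scatter. Adding the carbonyl to the 4-fluorophenyl group on the chain gives a 1.1-fold lower number from compound 2 to compound 4 (0.04 log units; within the scatter), so these two groups on sulfur do not separate either. The step from the free sulfur, an at least 1.4-fold lower number from compound 1 to compound 4 (0.15 log units; that floor lies within the scatter), is only a floor, as it rests on a limit: the limit of > 60000 nM in this assay, at which 1 of the 4 values shown sits.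

As far as these compounds go, whether an amine or a carboxylic acid at this aromatic carbon, or a longer chain on the sulfur, would move the number beyond the scatter stays open.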